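The compounds below may be only part of what the source reports. "The series", "measured", "known", "first", "only" and "open" are said of these compounds alone.

Three compounds built on a chloropurine core carrying a chloromethylbenzyl substituent were tested in a functional assay on SK-MEL-2 cells (Homo sapiens) for cytotoxicity, read by sulforhodamine B assay, with a stated time of 48 h; on this read-out higher numbers stand for weaker inhibition of growth and lower numbers for stronger inhibition of growth. Compound 1 `ClCc1ccc(Cn2cnc3c(Cl)ncnc32)cc1` gives 4360 nM. Compound 2 `Nc1nc(Cl)c2ncn(Cc3ccc(CCl)cc3)c2n1` differs from it by one change, (amino in place of hydrogen on an aromatic carbon), and gives 11500 nM; the step of a 2.6-fold higher number from compound 1 to compound 2 (0.42 log units; beyond the scatter) is beyond the scatter, so the added amino group weakened growth inhibition in this pair. Compound 3 `ClCc1ccccc1Cn1cnc2c(Cl)ncnc21` has the same atoms as compound 1 joined differently; how the two cores differ is not broken down here. In this assay compound 3 gives 2750 nM, a number within the scatter of that of compound 1 and beyond the scatter from that of compound 2.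

Compound 4 `Nc1nc(Cl)c2ncn(Cc3ccccc3CCl)c2n1` has not yet been measured. It stands to compound 3 as compound 2 stands to compound 1: the change is amino in place of hydrogen on an aromatic carbon, the same change at the same place. Because the earlier step was a 2.6-fold higher number from compound 1 to compound 2 (0.42 log units; beyond the scatter), a step of similar size is expected here, a 2.6-fold higher number from compound 3 to compound 4 (0.42 log units; beyond the scatter), though the scatter of the assay leaves the exact size uncertain. Compound 4 is therefore estimated to give 7200 nM, likely within 3500 nM to 15000 nM, in this assay.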

Compound 4, concentration for 50% growth inhibition: 18600 nM
For compound 4 the middle estimate is 2.6-fold (0.41 log units) below the measured one, and the stated range ends below it.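

In this assay, amino in place of hydrogen on an aromatic carbon again gave a higher number, a 6.8-fold higher number from compound 3 to compound 4 (0.83 log units; beyond the scatter), so the change weakened growth inhibition on both of the cores shown. The larger size of this second step cannot be taken as a real difference between the cores, as the two steps lie close enough for repeated measurement to account for the gap: the same change on two cores in this assay, a 2.6-fold higher number (0.42 log units; beyond the scatter) from compound 1 to compound 2 and a 6.8-fold higher number (0.83 log units; beyond the scatter) from compound 3 to compound 4, 2.6-fold (0.41 log units) apart, within the scatter of two such steps This shows that the direction of the change carried over from the core of compound 1 to the core of compound 3, and that one size fits both pairs within the scatter, but two pairs do not establish a rule for other cores or explain why the amino group has this effect.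

The compounds shown leave open whether a methylamino, dimethylamino or hydroxyl group at the same place would act as the amino group does. They also leave open how the series would respond if a methyl or methoxy group replaced the chloromethyl group.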